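Sulfonamide series on pancreatic cancer cells: aryl sulfonyl variation

The source may hold more compounds than are shown below. What is called first, only, known or untested is meant among the compounds shown, and "the series" means these compounds.

Two members of this series have been run in a functional assay on MIA PaCa-2 cells (Homo sapiens) for inhibition, read by MTT assay, with a stated time of 72 h; on this read-out higher numbers stand for weaker inhibition of growth and lower numbers for stronger inhibition of growth. Among the compounds with values here, compound 1 `Cc1ccc(C)c(S(=O)(=O)NCCCCCCNCc2ccc(Br)cc2)c1` gives 12000 nM in this assay, the highest of the two numbers; the only other measured compound, compound 2 `O=S(=O)(NCCNCc1ccc(-c2ccccc2)cc1)c1cc(C(F)(F)F)cc(C(F)(F)F)c1`, gives 2700 nM in this assay, a lower number that lies beyond the scatter from compound 1. Within the data shown here, compound 2 differs from compound 1 in several places at once, so no single step between measured compounds is available.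

The next compound to be measured is compound 3 `Cc1ccc(S(=O)(=O)NCCCCCCNCc2ccc(Br)cc2)cc1`, which differs from compound 1 in one place: 4-methylphenyl in place of 2,5-dimethylphenyl on a sulfonyl sulfur. The other parts of the shared core are unchanged.

Among the measured compounds shown here, no measured pair shows what this change does on its own, so the expectation for compound 3 rests on compound 1 and the size of the change. The step from compound 1 to compound 3 in this assay is expected to be small, of the order of the scatter or within it, with no preferred direction, a 1.1-fold higher number from compound 1 to compound 3 (0.03 log units; within the scatter). Compound 3 is therefore estimated at 13000 nM in this assay, with a range from 5000 nM to 35000 nM.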

Compound 3, concentration for 50% growth inhibition: 12300 nM
Estimate against measurement, compound 3: 1.1-fold (0.02 log units) above; measured number inside the range.
By their numbers in this assay, from the lowest: compound 2; then compounds 1 and 3 (each within the scatter of the next).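

In this assay, within the data shown here, the step of a 1.0-fold higher number from compound 1 to compound 3 (0.01 log units; within the scatter) is the first reading that isolates a single place, the aryl group on a sulfonyl sulfur. With the rest of the shared core held fixed, 2,5-dimethylphenyl and 4-methylphenyl cannot be told apart on this read-out, so this particular exchange leaves growth inhibition at the same level within the scatter. Nothing measured alongside these numbers bears on the reason for this result.

One exchange is a narrow sample of this place, and it leaves open whether the same flat reading extends to quite different groups on a sulfonyl sulfur, such as a naphthyl group, a pyridine ring or a phenyl ring carrying a carboxylic acid. It also leaves open whether 4-methylphenyl and 2,5-dimethylphenyl would still read alike with a longer chain in the shared core, or with an amide in place of its amine.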